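The compounds below may be only part of what the source reports. "The series", "measured", "known", "first", "only" and "open" are said of these compounds alone.

Measured compounds:
compound 1, `c1ccc2c(-c3cn4ccnc4c(-c4ccc5ncn(C6CCCCC6)c5c4)n3)cccc2c1`: 25.2%
compound 2, `CCc1ccc(-c2cn3ccnc3c(-c3ccc4ncn(Cc5ccccc5)c4c3)n2)cc1`: 47.9%

In a functional assay on CAKI-1 cells (Homo sapiens) for inhibition, read by sulforhodamine B assay, with a stated time of 48 h, tested at 10 uM (a higher number here means more inhibition at the concentration tested (going by the name of the read-out), a lower number less inhibition), compound 2 gives 47.9%, the higher of the two numbers, and it stands beyond the scatter from compound 1. Compound 3, `Cc1cccc(-c2cn3ccnc3c(-c3ccc4ncn(Cc5ccccc5)c4c3)n2)c1`, differs from compound 2 in one place: 3-methylphenyl in place of 4-ethylphenyl on an aromatic carbon. Among the compounds with values here, no measured pair isolates a change of this kind, so the size of the step is uncertain. A small loss or none beyond the scatter is expected, giving an estimated step of a number 7.9 percentage points lower from compound 2 to compound 3 (within the scatter). Compound 3 is therefore expected to reach about 40%, with a range from 20% to 60%.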

Compound 3, a percentage reported as inhibition, at one concentration (the size of the read-out at that concentration, not a potency): 24.8%
Compound 3: middle estimate off by 15.2 percentage points, on the high side; the measured number falls inside the stated range.
By their numbers in this assay, from the lowest: compounds 3 and 1 (each within the scatter of the next); then compound 2.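

In this assay, within the data shown here, the group on this aromatic carbon of the shared core clearly counts: 3-methylphenyl in place of 4-ethylphenyl gives a number 23.1 percentage points lower from compound 2 to compound 3 (beyond the scatter), the first single-place step. The change swaps ethyl for methyl and moves the substituent on the phenyl ring at once, so this step cannot tell which of the two matters. Nothing measured here bears on the reason for the drop.

Going by these compounds, whether 4-methylphenyl or 3-ethylphenyl would separate the two changes remains open. So does the effect of an amine or a carboxylic acid on that phenyl ring.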